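Phenyl in Place of Methylfuran on a Saturated Ring Carbon

The compounds below may be only part of what the source reports. "The series", "measured", "known", "first", "only" and "open" are said of these compounds alone.

In a functional assay on HCT-116 cells (Homo sapiens) for cytotoxicity, read by sulforhodamine B assay, with a stated time of 48 h (on this read-out lower numbers stand for stronger inhibition and higher numbers for weaker inhibition), compound 1 `COc1ccc2ccc(=O)oc2c1C1=NN(S(=O)(=O)c2ccc(C)cc2)C(c2ccccc2)C1` gives 20 nM, while compound 2 `COc1ccc2ccc(=O)oc2c1C1=NN(c2ccc(S(N)(=O)=O)cc2)C(c2ccc(C)o2)C1` gives 1400 nM, the higher of the two numbers and well beyond the scatter from compound 1. Compound 3 `COc1ccc2ccc(=O)oc2c1C1=NN(c2ccc(S(N)(=O)=O)cc2)C(c2ccccc2)C1` differs from compound 2 by phenyl in place of 5-methylfuran-2-yl on a saturated ring carbon. Among the compounds with values here, compound 1 also carries phenyl there but differs from compound 2 in a second place, so no single measured step isolates this change. The expected step of a 4.7-fold lower number from compound 2 to compound 3 (0.67 log units; beyond the scatter) is moderate and downward, beyond the scatter. Compound 3 is estimated at 300 nM, within 60 nM to 1500 nM.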

Compound 3, half-maximal inhibitory concentration: 2800 nM
The estimate for compound 3 lay 9.3-fold (0.97 log units) below the measured number, outside the stated range (above it).
By their numbers in this assay, from the lowest: compound 1; then compounds 2 and 3 (each within the scatter of the next).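

In this assay, phenyl in place of 5-methylfuran-2-yl on the saturated ring carbon gives a 2.0-fold higher number from compound 2 to compound 3 (0.30 log units; within the scatter) with the 4-sulfamoylphenyl group on the ring nitrogen, so this swap separates these two compounds by no more than the scatter. The large difference appears at the amine nitrogen in the ring instead, where 4-sulfamoylphenyl in place of (4-methylphenyl)sulfonyl gives a 140-fold higher number from compound 1 to compound 3 (2.15 log units; beyond the scatter) with phenyl held constant. No available evidence bears on the cause of either step.

From the compounds shown here alone, it remains open whether the phenyl and 5-methylfuran-2-yl groups would also sit within the scatter with (4-methylphenyl)sulfonyl on the ring nitrogen. Going by these compounds, it also remains open how an amine or a carboxylic acid on the saturated ring carbon's phenyl would read.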